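Flap endonuclease 1 inhibitors: change at the benzyl ring

The source may report more compounds than this note shows. Statements on the series, on what has been measured and on what is new or still open speak of the compounds shown alone.

compound 1 `CC(C)(C)c1cc2[nH]c(=O)n(O)c(=O)c2s1`: 0.135 nM
compound 2 `O=c1c2sccc2n(Cc2cccc(Br)c2)c(=O)n1O`: 0.072 nM

In an assay on isolated protein for inhibition of Flap endonuclease 1 (Homo sapiens) (on this read-out higher numbers stand for weaker inhibition and lower numbers for stronger inhibition), compound 1 gives 0.135 nM and compound 2 gives 0.072 nM; these two numbers lie within the usual scatter of each other, so compound 2 cannot be set apart from compound 1 in this assay. Compound 3 `NC(=O)c1ccc(-c2cccc(Cn3c(=O)n(O)c(=O)c4sccc43)c2)cc1` is not yet measured. It differs from compound 2 by 4-carbamoylphenyl in place of bromo on an aromatic carbon. For the measured compounds named here, no measured pair shows a step of this kind, so nothing fixes its size; a change no larger than the scatter, in either direction, is expected. Compound 3 is estimated at 0.1 nM in this assay, with a range of 0.03 nM to 0.5 nM, which means an expected step of a 1.4-fold higher number from compound 2 to compound 3 (0.14 log units; within the scatter).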

Compound 3, half-maximal inhibitory concentration: 0.003 nM
Compound 3: the middle estimate sits 33-fold (1.52 log units) above what was measured, outside the stated range (below it).
By their numbers in this assay, from the lowest: compound 3; then compounds 2 and 1 (each within the scatter of the next).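

In this assay, the position on the benzyl ring meta to a large group is not limited to a single bromo atom: 4-carbamoylphenyl there gives a 24-fold lower number from compound 2 to compound 3 (1.38 log units; beyond the scatter). For the compounds shown here, this is the first step to lie beyond the scatter, and it shows that this position can carry a second aromatic ring with a carbamoyl group. No available data account for the size of this step.

From the compounds shown here alone, whether the phenyl ring alone or the carbamoyl group carries the step remains open. Unsubstituted phenyl and 4-carboxyphenyl at this position would separate the two.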